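The source may report more compounds than this note shows. Statements on the series, on what has been measured and on what is new or still open speak of the compounds shown alone.

Compound 1 `CCCCc1cc2c(=O)c(-c3ccccc3)c(C)[nH]c2cc1OCCOc1ccccc1`: 23000 nM
Compound 2 `CCCCc1cc2c(=O)c(-c3ccc(OC(F)(F)F)cc3)c(C)[nH]c2cc1OCCOc1ccccc1`: 20000 nM
Compound 3 `CCCCc1cc2c(=O)c(-c3ccc(C)cc3C)c(C)[nH]c2cc1OCCOc1ccccc1`: 22000 nM

All three values come from an ADME assay on J774 cells (Mus musculus) for antiproliferative activity, with a stated time of 72 h; a higher number here means that more compound is needed for the effect, a lower number that less compound is needed. The compounds share one core and differ only in the aromatic group attached to it. Compound 3, at 22000 nM, cannot be told apart from the other two: the data show a 1.0-fold lower number from compound 1 to compound 3 (0.02 log units; within the scatter) and a 1.1-fold higher number from compound 2 to compound 3 (0.04 log units; within the scatter).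

Compound 4 `CCCCc1cc2c(=O)c(-c3c(C)noc3C)c(C)[nH]c2cc1OCCOc1ccccc1` has not yet been measured. It keeps the shared core and changes one group, with 3,5-dimethyl-1,2-oxazol-4-yl in place of 2,4-dimethylphenyl on an aromatic carbon.

The closest evidence is the set of changes already made to this aromatic group. Besides the two steps above, there is a 1.2-fold lower number from compound 1 to compound 2 (0.06 log units; within the scatter). None of these three steps goes beyond the scatter, so replacing this group has not yet moved the number in this assay. However, none of the measured compounds carries a five-membered aromatic ring here, so the data do not test this swap directly. The expected change is a 1.1-fold higher number from compound 3 to compound 4 (0.04 log units; within the scatter), which means no step beyond the scatter is expected, in either direction. Compound 4 is estimated at 24000 nM, with an expected range of 13000 nM to 45000 nM.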

Compound 4, half-maximal effective concentration: 22000 nM
Compound 4: the middle estimate sits 1.1-fold (0.04 log units) above what was measured; the measured number falls inside the stated range.
By their numbers in this assay, from the lowest: compounds 2, 3, 4 and 1 (each within the scatter of the next).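

For the compounds shown here, until now every group at this position was a six-membered aromatic ring of carbon only, so compound 4 is the first test of a five-membered aromatic ring with 2 hetero atoms here. In this assay the swap gives no change at the digits printed from compound 3 to compound 4 (within the scatter) and the comparisons with the other two compounds give a 1.1-fold higher number from compound 2 to compound 4 (0.04 log units; within the scatter) and a 1.0-fold lower number from compound 1 to compound 4 (0.02 log units; within the scatter) as well. Across these four compounds, then, neither the size of the aromatic ring nor the presence of hetero atoms in it moves the number beyond the scatter, and no measured evidence is available to explain this flat result.

The compounds shown leave open whether a group that is not a bare or methyl-type aromatic ring, such as a piperidine ring, a longer alkyl chain, or a phenyl ring carrying an amine or a carboxylic acid, would move the number beyond the scatter at this position. They also leave open whether changes elsewhere on the shared core, such as replacing the butyl chain, would shift the number more than any change to this aromatic group has so far.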